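Fluoro for Cyclopropyl on the Fused Ring: Expected Affinity

A few compounds are considered here, and "the series" means these few. Any claim that something is new, unique, unknown or untested is made for them only; others in the source may bear on it.

Compound 1 `Cc1ncccc1-c1cnc(NCc2c(F)cc(C3CC3)c3c2CCO3)n2cnnc12` has no number in an assay on isolated protein for binding affinity to Polycomb protein EED (Homo sapiens), read by surface plasmon resonance; a lower number here means tighter binding, a higher number weaker binding: in this assay compound 1 stands as "not determined" (no result reported), its result was not reported, so it stands nowhere on the scale. The same holds for compound 2 `Cc1ncccc1-c1cnc(NCc2c(F)cc(O)c3c2CCO3)n2cnnc12`, which likewise has no result in this assay, where compound 2 stands as "not determined" (no result reported). For the measured compounds named here, the only value belongs to compound 3 `COc1cc(F)c(CNc2ncc(-c3cccnc3C)c3nncn23)c2c1OCC2`, a close analogue on the shared core, and in this assay compound 3 gives 305000 nM, a very weak binder by any measure. Going by the values given here, no step between two measured compounds is available, so nothing is known about how changes on this part of the molecule move the number.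

Compound 4 `Cc1ncccc1-c1cnc(NCc2c(F)cc(F)c3c2CCO3)n2cnnc12` arises from compound 1 by the change (fluoro in place of cyclopropyl on an aromatic carbon), fluoro in place of cyclopropyl on an aromatic carbon. With compound 1 unmeasured and only the weak result of compound 3 as anchor, the direction of any step cannot be stated; a step within the scatter is the default expectation, with a broad range to either side. The whole series is expected to sit at the weak end of the scale, and compound 4 is estimated at 300000 nM, with a range from 50000 nM to 2000000 nM, and a real chance that only a limit is reported.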

Compound 4, dissociation constant: 1200 nM
The estimate for compound 4 lay 250-fold (2.40 log units) above the measured number; the measured number lies below the stated range.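

In this assay, for the compounds shown here, the aromatic carbon that carries cyclopropyl in compound 1 proves to be a place where a single change moves the number strongly: fluoro in place of methoxy gives a 250-fold lower number from compound 3 to compound 4 (2.41 log units; beyond the scatter) and is the only readable step. The series therefore does not sit uniformly at the weak end, since compound 4 gives 1200 nM on the shared core with only this one place changed from compound 3. No independent data on this result are available to explain the size of the step.

From the compounds shown here alone, the steps from compound 1 and from compound 2 to compound 4 cannot be read, so the standing of cyclopropyl and hydroxy against fluoro at this place remains unknown. Going by these compounds, a single step also cannot show whether fluoro favours binding or methoxy disfavours it, and it remains open what an unsubstituted carbon, a chloro group, a methyl group or an amine on this aromatic carbon would give.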